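The compounds below may be only part of what the source reports. "The series", "measured", "known", "first", "only" and "open" are said of these compounds alone.

Measured in a functional assay on MV4-11 cells (Homo sapiens) for antiproliferative activity, read by luminescence, with a stated time of 72 h; a higher number here means a weaker inhibitor, a lower number a stronger inhibitor:
- compound 1 `CC(=O)Oc1ccc(Cn2ccnc2)c2cccnc12`: 28500 nM
- compound 2 `Oc1ccc(Cn2nnc3ccccc32)c2cccnc12`: 1000 nM

In this assay, compound 1 has the higher of the two numbers, and the gap down to compound 2 lies beyond the scatter. Compound 3 `CC(C)(C)OC(=O)Oc1ccc(Cn2ccnc2)c2cccnc12` keeps the core of compound 1, with tert-butoxy in place of methyl on a carbonyl carbon. Going by the values given here, no measured pair shows this change. The expectation therefore rests only on compound 1 at 28500 nM, its closest measured neighbour. The estimated step of a 1.4-fold lower number from compound 1 to compound 3 (0.15 log units; within the scatter) is small, within the scatter, with no firm direction. For compound 3 the expected value is 20000 nM, with an estimated range of 6000 nM to 60000 nM.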

Compound 3, half-maximal inhibitory concentration: 11500 nM
Estimate against measurement, compound 3: 1.7-fold (0.24 log units) above; the measured number falls inside the stated range.
By their numbers in this assay, from the lowest: compound 2; then compound 3; then compound 1.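

In this assay tert-butoxy in place of methyl on a carbonyl carbon gives a 2.5-fold lower number from compound 1 to compound 3 (0.39 log units; beyond the scatter) as a modest step. This position therefore accepts the larger tert-butoxycarbonyl in place of acetyl with no loss, and the number moves down rather than up. Nothing available accounts for the step.

From the compounds shown here alone, whether an amine or a longer chain on this carbonyl carbon would extend the step remains open. Also open, going by these compounds, is whether the same change would give a similar step on another core.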